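This account rests on a few compounds, and the source may have more. Where it says the series, first, only, none or still open, it means among the compounds named here.

Compound 2 `C=CCN(C)/N=N/c1ccc(C(=O)O)cc1` shares its core with compound 1 `CCCN(C)/N=N/c1ccc(C(=O)O)cc1` and differs from it only in the chain on the amine nitrogen. In a physicochemical assay for lipophilicity, in phosphate buffer, measured as octanol-water partition, at pH 7.4 (a lower number here means a more polar compound, a higher number a more lipophilic compound), compound 2 gives 0.32, and in this assay compound 1 gives 0.46; the step of a number 0.14 log units lower from compound 1 to compound 2 (within the scatter) lies within the scatter, so the two compounds stand together on the numbers shown, with compound 2 carrying the smaller of the two values.

Compound 3 `CCCCCCCN(C)/N=N/c1ccc(C(=O)O)cc1` has not yet been measured. Its change from compound 2 is hexyl in place of vinyl on a saturated chain carbon bound to an amine nitrogen. Among the compounds with values here, the only measured step at this place, a number 0.14 log units lower from compound 1 to compound 2 (within the scatter), exchanged one two-carbon group for another and stayed within the scatter; no measured step covers a lengthening of the chain by this count of carbons. What can be said therefore rests on the change itself and on that single step. For compound 3 an upward step a number 2.08 log units higher from compound 2 to compound 3 (beyond the scatter) in this assay is expected, beyond the scatter. The estimate for compound 3 in this assay is 2.4, with a range from 1.7 to 3.1.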

Compound 3, distribution coefficient: 2.58
For compound 3 the middle estimate is 0.18 log units below the measured one; low and high end bracket the measured number.
By their numbers in this assay, from the lowest: compounds 2 and 1 (each within the scatter of the next); then compound 3.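

Within the data shown here, until now, the only comparison at this position was a pair standing together within the scatter, and compound 3 shows that the chain on the amine nitrogen can also carry a large step in this assay. Hexyl in place of vinyl gives a number 2.26 log units higher from compound 2 to compound 3 (beyond the scatter), and butyl in place of hydrogen on a saturated chain carbon, three bonds along the chain from an amine nitrogen, gives a number 2.12 log units higher from compound 1 to compound 3 (beyond the scatter), so compound 3 stands clearly apart from both earlier compounds, which remain together. The data offer no measured finding that would account for the size of these steps.

The compounds shown leave open how the number runs with chain length, whether it climbs evenly through chains of intermediate length or mostly over part of that range, and whether a longer chain would extend the trend. They also leave open what a branched chain, a chain ending in an amine or a hydroxyl group, or a ring in place of the chain would give at this position.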